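A few compounds are considered here, and "the series" means these few. Any claim that something is new, unique, unknown or untested is made for them only; others in the source may bear on it.

Working notes on the series.

Three compounds share one core and differ only in the group on a nitrogen on an aromatic ring. In a functional assay on MCF7 cells (Homo sapiens) for cytotoxicity, read by MTT assay, with a stated time of 72 h (a lower number here means a stronger inhibitor, a higher number a weaker inhibitor), compound 1 `CCCCCCCCNc1nc(SCc2ccc(C(F)(F)F)cc2)nc2ccccc12` gives 26100 nM. Compound 2 `FC(F)(F)c1ccc(CSc2nc(Nc3cccc(Br)c3)c3ccccc3n2)cc1` gives 25600 nM in this assay. Compound 3 `Fc1ccc(Nc2nc(SCc3ccc(C(F)(F)F)cc3)nc3ccccc23)cc1` gives 36300 nM in this assay. Compound 3 cannot be separated from either neighbour: a 1.4-fold higher number from compound 1 to compound 3 (0.14 log units; within the scatter) and a 1.4-fold higher number from compound 2 to compound 3 (0.15 log units; within the scatter), and the remaining pair shows a 1.0-fold lower number from compound 1 to compound 2 (0.01 log units; within the scatter). All three swaps at this position, whether a chain for an aryl group or one aryl group for another, leave this assay unmoved beyond the scatter.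

Compound 4 `COc1ccc(Nc2nc(SCc3ccc(C(F)(F)F)cc3)nc3ccccc23)cc1OC` follows the same route: 3,4-dimethoxyphenyl in place of 4-fluorophenyl on a nitrogen on an aromatic ring. Among the compounds with values here, no measured compound carries hydrogen-bond acceptors at this position, so nothing in the data speaks to that part of the change. The three steps that bear on it were all within the scatter, so the step from compound 3 to compound 4 is expected to be a 1.0-fold lower number from compound 3 to compound 4 (0.02 log units; within the scatter), with no direction favoured. Compound 4 is therefore estimated at 35000 nM in this assay, within 14000 nM to 90000 nM.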

Compound 4, half-maximal inhibitory concentration: > 50000 nM
Compound 4: only a limit was reported; the forecaster's own chance of this, stated with the estimate: 10%; middle value at least 1.4-fold (0.15 log units) away from the limit.
By their numbers in this assay, from the lowest: compounds 2, 1 and 3 (each within the scatter of the next). At a limit, above all of these: compound 4.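

In this assay compound 4 alone stands at a limit: the limit of > 50000 nM in this assay, at which 1 of the 4 values shown sits. Only floors can be given for its steps, namely an at least 1.3-fold higher number from compound 3 to compound 4 (0.13 log units; that floor lies within the scatter) and an at least 1.9-fold higher number from compound 2 to compound 4 (0.29 log units; that floor lies within the scatter) and an at least 1.9-fold higher number from compound 1 to compound 4 (0.28 log units; that floor lies within the scatter), so 3,4-dimethoxyphenyl is not shown to differ beyond the scatter from 4-fluorophenyl, 3-bromophenyl or octyl, although all three floors point towards a weaker inhibitor. Within the data shown here, this is the first group at this position with hydrogen-bond acceptors, and it gives no sign of a stronger inhibitor.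

Going by these compounds, how far compound 4 lies past its limit remains open, as does which of the two methoxy groups matters. Also open, on these data alone, is whether a single methoxy group, an amine or a carboxylic acid on the phenyl group at this position would move the number beyond the scatter in either direction.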